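A few compounds are considered here, and "the series" means these few. Any claim that something is new, unique, unknown or untested is made for them only; others in the source may bear on it.

The measured compounds, all tested in a functional assay on MCF7 cells (Homo sapiens) for inhibition, read by sulforhodamine B assay; on this read-out lower numbers stand for stronger inhibition and higher numbers for weaker inhibition:

compound 1 `O=C1C(Nc2ccc(Br)cc2)=CC(=O)c2c1nc1n2[C@H]2OC[C@@H](O)[C@H]2OC1`, 4330 nM
compound 2 `COc1ccccc1NC1=CC(=O)c2c(nc3n2[C@H]2OC[C@@H](O)[C@H]2OC3)C1=O`, 6580 nM
compound 3 `COc1ccccc1NC1=CC(=O)c2nc3n(c2C1=O)[C@H]1OC[C@@H](O)[C@H]1OC3`, for which only a limit is known

Compound 3 does not give a number in this assay but a limit, > 4000 nM, which is the limit of > 4000 nM in this assay, at which 1 of the 3 values shown sits. Compound 4 `O=C1C=C(Nc2ccc(Br)cc2)C(=O)c2c1nc1n2[C@H]2OC[C@@H](O)[C@H]2OC1` has not yet been measured.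

Compounds 1 and 2 differ in one place: 4-bromophenyl in place of 2-methoxyphenyl on an amine nitrogen. In this assay this gave a 1.5-fold lower number from compound 2 to compound 1 (0.18 log units; within the scatter), so the two numbers are not told apart here. Compounds 2 and 3 are built from the same atoms joined differently; the difference between the two cores is not broken down here. Compound 4 relates to compound 3 exactly as compound 1 relates to compound 2: 4-bromophenyl in place of 2-methoxyphenyl on an amine nitrogen, at the same place on the amine nitrogen, so it is the same change carried over onto the core of compound 3.

Going by the values given here, the only guide to what this change does is the step between compounds 2 and 1, and because a 1.5-fold lower number from compound 2 to compound 1 (0.18 log units; within the scatter) lay within the scatter, the step that the limit leaves unreadable from compound 3 to compound 4 is expected to be small as well. Since compound 3 itself gave only a limit, compound 4 is expected to sit near or beyond that limit too, with an estimate of 6000 nM, roughly between 3000 nM and 15000 nM.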

Compound 4, half-maximal inhibitory concentration: 2580 nM
Compound 4: the middle estimate sits 2.3-fold (0.37 log units) above what was measured, and the stated range ends above it.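

Compound 3 has only a limit, not a number, in this assay: it reads > 4000 nM. Carried onto the core of compound 3, the change of 2-methoxyphenyl to 4-bromophenyl on the amine nitrogen gives an at least 1.5-fold lower number from compound 3 to compound 4 (0.19 log units; that floor lies within the scatter), and the real step could be that size or larger, as only its smallest possible size can be read. This shows that the change does not leave compound 4 beyond the limit, but it does not show that the change acts alike on both cores, as the comparison stays unsettled: the same change on two cores in this assay, a 1.5-fold lower number (0.18 log units; within the scatter) from compound 2 to compound 1 and an at least 1.5-fold lower number (0.19 log units; that floor lies within the scatter) from compound 3 to compound 4; the limit leaves it open whether they differ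

The change swaps one whole group for another, so the compounds shown cannot separate what losing the 2-methoxyphenyl group contributes from what gaining the 4-bromophenyl group contributes. A plain phenyl ring on the amine nitrogen, or a phenyl ring carrying a carboxylic acid or a dimethylamino group, would help to show how far the read-out on each core depends on this group at all.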